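The source may hold more compounds than are shown below. What is called first, only, known or untested is meant among the compounds shown, and "the series" means these compounds.

In a functional assay on SK-MEL-28 cells (Homo sapiens) for cytotoxicity, read by CCK-8 assay, with a stated time of 24 h (a lower number here means a stronger inhibitor, a higher number a weaker inhibitor), compound 1 `COc1ccccc1Oc1c(N)nc(-c2ccccc2)nc1OCCO` gives > 80000 nM, which is a limit of the assay and not a number. Compound 2 `COc1ccccc1Oc1c(N)nc(-c2cccc(Cl)c2)nc1OCCO` gives 4170 nM. Compound 3 `COc1ccccc1Oc1c(N)nc(-c2cccc(Br)c2)nc1OCCO` gives 4040 nM, and the step of a 1.0-fold lower number from compound 2 to compound 3 (0.01 log units; within the scatter) leaves the two level. The large steps are an at least 19-fold lower number from compound 1 to compound 2 (1.28 log units; beyond the scatter) and an at least 19-fold lower number from compound 1 to compound 3 (1.29 log units; beyond the scatter), and the swap of chloro for bromo adds nothing beyond that. Compound 4 `COc1ccccc1Oc1c(N)nc(-c2ccc(Br)cc2)nc1OCCO` differs by 4-bromophenyl in place of 3-bromophenyl on an aromatic carbon, with 4-bromophenyl in place of 3-bromophenyl on an aromatic carbon. Among the compounds with values here, no measured step moves a group in this way, so the measured steps show only what having chloro or bromo present gives, and compound 4 keeps its bromo. The estimated change, a 1.1-fold higher number from compound 3 to compound 4 (0.05 log units; within the scatter), is expected to stay within the scatter, with no firm direction. For compound 4 the expected value is 4500 nM, with an estimated range of 1500 nM to 14000 nM.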

Compound 4, half-maximal inhibitory concentration: 4400 nM
Compound 4: middle estimate off by 1.0-fold (0.01 log units), on the high side, and the stated range covers the measured number.
By their numbers in this assay, from the lowest: compounds 3, 2 and 4 (each within the scatter of the next). At a limit, above all of these: compound 1.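

Shifting the bromo from 3-bromophenyl to 4-bromophenyl at this position leaves the number level, with a 1.1-fold higher number from compound 3 to compound 4 (0.04 log units; within the scatter), and the change from 3-chlorophenyl gives a 1.1-fold higher number from compound 2 to compound 4 (0.02 log units; within the scatter). The large drop from the plain phenyl therefore holds with the halogen in either place, with an at least 18-fold lower number from compound 1 to compound 4 (1.25 log units; beyond the scatter). Compound 1 stands at a limit of the assay and not at a number: the limit of > 80000 nM in this assay, at which 1 of the 4 values shown sits.

As far as these compounds go, whether an amine or a carboxylic acid on this phenyl would keep the number level stays open. So does the effect of a longer chain in place of the 2-hydroxyethoxy group.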